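The compounds below may be only part of what the source reports. "The series", "measured", "known", "first", "only" and "open" are said of these compounds alone.

Measured in an ADME assay on a cell-free system (plasma, Rattus norvegicus) for metabolic stability, read by LC-MS, with a stated time of 120 min, tested at 200 uM; on this read-out lower numbers stand for a shorter-lived compound and higher numbers for a longer-lived compound:
- compound 1 `N[C@@H](CCC(=O)OC[C@H]1O[C@@H](n2cc(F)c(=O)[nH]c2=O)C[C@@H]1OC(=O)CC[C@H](N)C(=O)O)C(=O)O`: 1.13 h
- compound 2 `N[C@@H](CCC(=O)O[C@H]1C[C@H](n2cc(F)c(=O)[nH]c2=O)O[C@@H]1CO)C(=O)O`: 1.62 h

Going by the values given here, compound 2 gives 1.62 h, within the scatter of compound 1, the only other compound measured. The next compound is compound 3 `CC(C)[C@H](N)C(=O)O[C@H]1C[C@H](n2cc(F)c(=O)[nH]c2=O)O[C@@H]1CO`, with 1-amino-2-methylpropyl in place of 3-amino-3-carboxypropyl on a carbonyl carbon. Among the compounds with values here, one measured step bears on this only loosely: a 1.4-fold higher number from compound 1 to compound 2 (0.16 log units; within the scatter). That step removes a whole (3-amino-3-carboxypropyl)carbonyl and stays within the scatter. Within the data shown here, no measured compound carries 1-amino-2-methylpropyl, so the data give no direction for the exchange, and no change beyond the scatter is expected in this assay. The expected step is a 1.2-fold lower number from compound 2 to compound 3 (0.10 log units; within the scatter). The estimate for compound 3 is 1.3 h, with an expected range of 0.5 h to 3.5 h.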

Compound 3, half-life: 1.09 h
Compound 3: the middle estimate sits 1.2-fold (0.08 log units) above what was measured, and the stated range covers the measured number.
By their numbers in this assay, from the lowest: compounds 3, 1 and 2 (each within the scatter of the next).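

In this assay the exchange of 3-amino-3-carboxypropyl for 1-amino-2-methylpropyl on a carbonyl carbon gives a 1.5-fold lower number from compound 2 to compound 3 (0.17 log units; within the scatter) and so stays inside the usual spread of repeats. The earlier step showed only the loss of a whole (3-amino-3-carboxypropyl)carbonyl, whereas this pair shows that replacing the group, from 7 heavy atoms to 5 and from 2 hydrogen-bond donors to 1, does not separate the two compounds on this read-out. No measurement shown gives a reason for this result.

Open, as far as these compounds go, is whether a group without an amine, such as acetyl, or a longer chain such as 5-aminopentyl, on the same carbonyl carbon would also stay within the scatter of compound 2. From the compounds shown here alone, the opposite configuration at the amino-bearing carbon of 1-amino-2-methylpropyl also remains open.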